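Extending the Amine Side Chain on a Urea-Bearing Core

A few compounds are considered here, and "the series" means these few. Any claim that something is new, unique, unknown or untested is made for them only; others in the source may bear on it.

Compound 1, `CN(C)CCNc1nc(-c2ccc(NC(=O)Nc3ccc(F)cc3)cc2)nc2c(Cl)c(Cl)sc12`, gives 590 nM in a functional assay on NCI-H460 cells (Homo sapiens) for cytotoxicity, read by MTT assay, with a stated time of 72 h; on this read-out higher numbers stand for weaker inhibition and lower numbers for stronger inhibition.
Compound 2, `CN(C)CCNc1nc(-c2ccc(NC(=O)Nc3ccc(Cl)cc3)cc2)nc2c(Cl)c(Cl)sc12`, gives 300 nM in this assay.
Compound 3, `CN(C)CCNc1nc(-c2ccc(NC(=O)Nc3ccccc3Cl)cc2)nc2c(Cl)c(Cl)sc12`, gives 440 nM in this assay.

Compound 2 has the lowest of the three numbers, but this means little: a 2.0-fold lower number from compound 1 to compound 2 (0.29 log units; within the scatter) and a 1.5-fold higher number from compound 2 to compound 3 (0.17 log units; within the scatter) both lie within the scatter, as does a 1.3-fold lower number from compound 1 to compound 3 (0.13 log units; within the scatter), so the three measured compounds cannot be told apart on these results.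

Compound 4, `CCN(CC)CCNc1nc(-c2ccc(NC(=O)Nc3ccc(Cl)cc3)cc2)nc2c(Cl)c(Cl)sc12`, is built from compound 2 by one change: diethylamino in place of dimethylamino on a saturated chain carbon, two bonds along the chain from a nitrogen on an aromatic ring. All three measured steps concern the phenyl ring attached to the urea nitrogen on the other side of the shared core, and none of them touches the amine-bearing chain. Within the data shown here, there is therefore no measured step that bears on this change, and the expectation can rest only on the general picture that small changes have so far stayed within the scatter. The step expected for compound 4 is a 1.1-fold higher number from compound 2 to compound 4 (0.03 log units; within the scatter), that is, no change beyond the scatter. Compound 4 is accordingly estimated to give 320 nM, with a likely range from 120 nM to 850 nM in this assay.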

Compound 4, half-maximal inhibitory concentration: 320 nM
Estimate against measurement, compound 4: no gap at the digits printed, within the range that was stated.
By their numbers in this assay, from the lowest: compounds 2, 4, 3 and 1 (each within the scatter of the next).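

Among these compounds, compound 4 gives the first measured look at the amine end of the side chain, since all the earlier steps changed only the phenyl ring on the urea, and placing diethylamino where dimethylamino stood gives a 1.1-fold higher number from compound 2 to compound 4 (0.03 log units; within the scatter) in this assay on the shared core. At this position, with a 4-chlorophenyl group on the urea, the two amine groups therefore cannot be told apart on this read-out, so the exchange of the methyl groups for ethyl groups on this nitrogen leaves no mark that rises above the ordinary spread of repeat measurements. No accompanying measurement on these compounds offers an explanation for this result, so it stands as an observation only.

Still open, from the compounds shown here alone, is whether a more drastic change at this end, such as a pyrrolidine or morpholine ring in place of the diethylamino group, a primary amine, or a longer chain carrying the amine, would also leave the number where it is. Also open, going by these compounds, is whether the same exchange of dimethylamino for diethylamino would read alike with a 4-fluorophenyl or 2-chlorophenyl group on the urea.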